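The source may report more compounds than this note shows. Statements on the series, on what has been measured and on what is new or still open speak of the compounds shown alone.

In an assay on isolated protein for inhibition of histone deacetylase 4 (Homo sapiens), with a stated time of 1 h (on this read-out lower numbers stand for stronger inhibition and higher numbers for weaker inhibition), the measured compounds are:

compound 1, `Cc1ccc(NC(=O)COc2ccc3cc(/C=C4/SC(=O)NC4=O)ccc3c2)cc1`: 1700 nM
compound 2, `Cc1ccc(NC(=O)COc2ccc3cc(/C=C4/SC(=O)NC4=O)ccc3c2)cc1Cl`: 1100 nM
compound 3, `O=C(COc1ccc2cc(/C=C3/SC(=O)NC3=O)ccc2c1)Nc1cccc(Cl)c1`: 3800 nM

Compound 1 stands second highest of these three numbers. Its nearest neighbour is compound 2, with a 1.5-fold lower number from compound 1 to compound 2 (0.19 log units; within the scatter), and its furthest is compound 3, with a 2.2-fold higher number from compound 1 to compound 3 (0.35 log units; beyond the scatter). Compound 4, `O=C(COc1ccc2cc(/C=C3/SC(=O)NC3=O)ccc2c1)Nc1ccccn1`, has not been measured. It differs from compound 1 by pyridin-2-yl in place of 4-methylphenyl on an amide-type nitrogen. Within the data shown here, the one measured step that touches the same amide-type nitrogen is a 2.2-fold higher number from compound 1 to compound 3 (0.35 log units; beyond the scatter), a modest move to a higher number; the related step of a 3.5-fold higher number from compound 2 to compound 3 (0.54 log units; beyond the scatter) points the same way. A modest rise in the number is therefore expected for compound 4. Compound 4 is estimated at 3000 nM, with a range from 1500 nM to 6000 nM. This estimate corresponds to an expected step of a 1.8-fold higher number from compound 1 to compound 4 (0.25 log units; within the scatter).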

Compound 4, half-maximal inhibitory concentration: 17000 nM
Compound 4: middle estimate off by 5.7-fold (0.75 log units), on the low side; the whole stated range lies below it.
By their numbers in this assay, from the lowest: compounds 2 and 1 (each within the scatter of the next); then compound 3; then compound 4.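

In this assay, pyridin-2-yl on the amide-type nitrogen gives a 10-fold higher number from compound 1 to compound 4 (1.00 log units; beyond the scatter), a 4.5-fold higher number from compound 3 to compound 4 (0.65 log units; beyond the scatter) and a 15-fold higher number from compound 2 to compound 4 (1.19 log units; beyond the scatter). Each of these steps is larger than any step among the three phenyl-bearing compounds, so this position proves more sensitive to exchanging the ring itself than to changing the substituents on the phenyl ring. No available evidence bears on the reason for this rise. Going by these compounds, it remains open whether plain phenyl or pyrimidinyl on the same nitrogen would fall nearer compound 3 or compound 4.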